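A few compounds are considered here, and "the series" means these few. Any claim that something is new, unique, unknown or untested is made for them only; others in the source may bear on it.

The three compounds measured so far in a functional assay on the whole organism (stomach) for inhibition, with Canis familiaris (Canis lupus familiaris) as the target, at a dose of 5 mg/kg by the intravenous route; on this read-out higher numbers stand for a stronger effect at the one dose given and lower numbers for a weaker effect:

compound 1 `CC(=O)c1c(C)nc2c(OCc3ccccc3)cccn12` gives 9%
compound 2 `Cc1nc2c(OCc3ccccc3)cccn2c1CO` gives 80%
compound 3 `CCOCc1c(C)nc2c(OCc3ccccc3)cccn12` gives 35%

Compound 3 stands second of the three. The step of a number 26 percentage points higher from compound 1 to compound 3 (beyond the scatter) lifts it above compound 1, while the step of a number 45 percentage points lower from compound 2 to compound 3 (beyond the scatter) leaves it well below compound 2. The group on this aromatic carbon thus swings the response across a wide span, and the step of a number 71 percentage points higher from compound 1 to compound 2 (beyond the scatter) is the largest of the three.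

Compound 4 `Cc1nc2c(OCc3ccccc3)cccn2c1Cl` has not yet been measured. It differs from compound 3 in one place: chloro in place of ethoxymethyl on an aromatic carbon. Within the data shown here, none of the measured steps introduces chloro, so no step bears directly on this change. What the measured steps do show is that exchanging the group on this carbon moved the response by large amounts in both directions. With nothing to point the way, a change to a group unlike any of the three seen is expected to move the number, but the direction is open, and the range must be wide. Compound 4 is therefore expected to give about 30%, between 5% and 65%. The expected step is a number 5 percentage points lower from compound 3 to compound 4 (within the scatter).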

Compound 4, a percentage reported as inhibition, in the whole organism at one dose (the size of the read-out at that dose, not a potency): 37%
Compound 4: middle estimate off by 7 percentage points, on the low side; the range from low to high includes it.
By their numbers in this assay, from the lowest: compound 1; then compounds 3 and 4 (each within the scatter of the next); then compound 2.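

In this assay, the step of a number 2 percentage points higher from compound 3 to compound 4 (within the scatter) shows that chloro and ethoxymethyl cannot be told apart on this aromatic carbon, even though chloro has 1 heavy atom and 0 hydrogen-bond acceptors while ethoxymethyl has 4 heavy atoms and 1 hydrogen-bond acceptor. The step of a number 43 percentage points lower from compound 2 to compound 4 (beyond the scatter) and the step of a number 28 percentage points higher from compound 1 to compound 4 (beyond the scatter) then set chloro, like ethoxymethyl, well short of hydroxymethyl yet clear of acetyl, so among these four groups the response falls into three levels rather than following the size of the group. Nothing available explains why these groups fall where they do.

The compounds shown leave open whether the high response of compound 2 is peculiar to hydroxymethyl or would be shared by an aminomethyl group, a longer hydroxyethyl chain or a carboxylic acid on this carbon, and whether bromo or a plain hydrogen would sit level with chloro. Since each figure comes from a single dose, they also leave open how the potencies of compound 3 and compound 4 compare.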